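The source may report more compounds than this note shows. Statements on the series, on what has been measured and on what is new or still open speak of the compounds shown alone.

Of the compounds shown here, two have been measured so far. In a functional assay on HCT-116 cells (Homo sapiens) for cytotoxicity, read by MTT assay, with a stated time of 24 h (on this read-out lower numbers stand for stronger inhibition and higher numbers for weaker inhibition), compound 2 `COc1ccc(/C=C\C(=O)O)c(OCc2cn(-c3cccnc3Cl)nn2)c1CC=C(C)C` gives 23000 nM, the highest of the two numbers in hand. Among the compounds with values here, its nearest neighbour is compound 1 `COc1ccc(/C=C\C(=O)O)c(OCc2cn(-c3ccc(NC(=O)c4ccccc4)cc3)nn2)c1CC=C(C)C`, which in this assay gives 16400 nM; the gap between these two values lies within the scatter of the method, so the pair shows only that both compounds are weak inhibitors of roughly the same standing, and no ordering between them can be claimed. Within the data shown here, no step between compounds that differ in one place is available from these data.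

The next compound, compound 3 `COc1ccc(/C=C\C(=O)O)c(OCc2cn(-c3ccc(C#N)cc3)nn2)c1CC=C(C)C`, is reached from compound 2 by a single change: 4-cyanophenyl in place of 2-chloropyridin-3-yl on an aromatic nitrogen. Both aromatic groups examined so far on this aromatic nitrogen gave values within the scatter of one another, and nothing in the data singles out the 4-cyanophenyl group as different in kind. On that basis the change is expected to be small, without a direction beyond the scatter, amounting to a 1.2-fold lower number from compound 2 to compound 3 (0.06 log units; within the scatter). Compound 3 is therefore estimated to give 20000 nM in this assay, with a range from 8000 nM to 50000 nM.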

Compound 3, half-maximal inhibitory concentration: 21000 nM
For compound 3 the middle estimate is 1.1-fold (0.02 log units) below the measured one; low and high end bracket the measured number.
By their numbers in this assay, from the lowest: compounds 1, 3 and 2 (each within the scatter of the next).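

In this assay the replacement of 2-chloropyridin-3-yl by 4-cyanophenyl on an aromatic nitrogen of the five-membered ring amounts to a 1.1-fold lower number from compound 2 to compound 3 (0.04 log units; within the scatter) and so gives a third aromatic group at this position with no separation from the others. The comparison with the benzamide adds a second change on the same phenyl ring: cyano in place of benzamido on an aromatic carbon gives a 1.3-fold higher number from compound 1 to compound 3 (0.11 log units; within the scatter) and thus shows that these two substituents cannot be told apart in this read-out, although they differ greatly in size. No measurement at hand accounts for this flat picture.

On these data alone, all three compounds carry an aromatic ring at this position, so it remains open whether a saturated group there, such as a cyclohexyl ring or a plain alkyl chain, or an amine or carboxylic acid on the phenyl ring, would move the value beyond the scatter. As far as these compounds go, the carboxylic acid of the shared core is also the same throughout, and what its methyl ester would give is equally open.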